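From 3-bromophenyl to 4-methoxyphenyl on the shared core

The source may report more compounds than this note shows. Statements on the series, on what has been measured and on what is new or still open speak of the compounds shown alone.

In a functional assay on PANC-1 cells (Homo sapiens) for inhibition, read by MTT assay, with a stated time of 24 h (on this read-out lower numbers stand for stronger inhibition and higher numbers for weaker inhibition), compound 1 (`CC1(C)[C@H]2CC[C@]1(C)N(Cc1cn(-c3ccccc3F)nn1)C(=O)C2`) gives 150 nM and compound 2 (`CC1(C)[C@H]2CC[C@]1(C)N(Cc1cn(-c3cccc(Br)c3)nn1)C(=O)C2`) gives 90 nM on the same read-out. Going by the values given here, these are the only two numbers available, and they lie within the scatter of each other, so compound 2 cannot be told apart from compound 1.

Compound 3 (`COc1ccc(-n2cc(CN3C(=O)C[C@@H]4CC[C@@]3(C)C4(C)C)nn2)cc1`) keeps the shared core and carries 4-methoxyphenyl in place of 3-bromophenyl on an aromatic nitrogen of the five-membered aromatic ring with 3 nitrogen. Among the compounds with values here, one measured step bears on this change. It concerns the same place, with 3-bromophenyl in place of 2-fluorophenyl, and amounts to a 1.7-fold lower number from compound 1 to compound 2 (0.22 log units; within the scatter) in all. Within the data shown here, no measured compound carries 4-methoxyphenyl, so the direction remains open, and no shift beyond the scatter is expected in this assay here. The estimated move is a 1.3-fold higher number from compound 2 to compound 3 (0.12 log units; within the scatter) and stays within that scatter. For compound 3 the expected value is 120 nM in an estimated range from 45 nM to 320 nM on this read-out.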

Compound 3, half-maximal inhibitory concentration: 330 nM
Estimate against measurement, compound 3: 2.8-fold (0.44 log units) below, and the stated range ends below it.
By their numbers in this assay, from the lowest: compounds 2 and 1 (each within the scatter of the next); then compound 3.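

The group on this aromatic nitrogen of the five-membered ring turns out not to be neutral in this assay: the two halogen-bearing phenyl groups could not be told apart, whereas 4-methoxyphenyl gives a 3.7-fold higher number from compound 2 to compound 3 (0.56 log units; beyond the scatter) and a 2.2-fold higher number from compound 1 to compound 3 (0.34 log units; beyond the scatter). Both steps are modest, but each lies beyond the scatter, so compound 3 is separated from both earlier compounds and the position shows a real, if limited, sensitivity to the choice of aryl group, with the higher number marking weaker inhibition. No independent measurement bears on why the number moves at this position, so the change remains an observation about these three compounds alone.

Going by these compounds, what remains open is which feature of the swap matters, since 4-methoxyphenyl differs from 3-bromophenyl both in the group carried on the phenyl ring and in where that group sits. A 4-bromophenyl or a 3-methoxyphenyl group on the same nitrogen would separate those two features, and a 4-aminophenyl group would show whether another non-halogen group follows compound 3 or stays with compound 1 and compound 2.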